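Cyano in Place of Bromo on the Aromatic Ring

A few compounds are considered here, and "the series" means these few. Any claim that something is new, unique, unknown or untested is made for them only; others in the source may bear on it.

Of the compounds shown here, three sharing one core have been measured in an assay for displacement of a labelled ligand from melanin-concentrating hormone receptor 1 (Homo sapiens), read by fluorescence; on this read-out lower numbers stand for stronger inhibition and higher numbers for weaker inhibition. Compound 1 `CC(=O)Nc1cccc(C2CCN(CCCn3c(-c4ccccc4)nc4ccccc43)CC2)c1` gives 2 nM in this assay. Compound 2 `CC(=O)Nc1cccc(C2CCN(CCCn3c(-c4ccc(F)cc4)nc4ccccc43)CC2)c1` gives 56 nM, and compound 3 `CC(=O)Nc1cccc(C2CCN(CCCn3c(-c4ccc(Br)cc4)nc4ccccc43)CC2)c1` gives 5 nM. Among these three numbers compound 3 stands second highest: the step of a 2.5-fold higher number from compound 1 to compound 3 (0.40 log units; beyond the scatter) is modest, whereas the step of an 11-fold lower number from compound 2 to compound 3 (1.05 log units; beyond the scatter) is large, and the step of a 28-fold higher number from compound 1 to compound 2 (1.45 log units; beyond the scatter) shows how far the fluoro analogue falls from the parent.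

Compound 4 `CC(=O)Nc1cccc(C2CCN(CCCn3c(-c4ccc(C#N)cc4)nc4ccccc43)CC2)c1` carries the change (cyano in place of bromo on an aromatic carbon). Going by the values given here, no measured step involves a cyano group, so the bearing steps are only indirect: both substituents on this aromatic carbon that have been tried raised the number in this assay, by a modest amount for bromo in compound 3 and by a large amount for fluoro in compound 2. The expectation for compound 4 is therefore a higher number than compound 3, with the step of a 4.0-fold higher number from compound 3 to compound 4 (0.60 log units; beyond the scatter) estimated to lie beyond the scatter but short of the loss seen in compound 2. Compound 4 is accordingly estimated at 20 nM, with a range from 4 nM to 100 nM.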

Compound 4, half-maximal inhibitory concentration: 16 nM
Compound 4: the middle estimate sits 1.3-fold (0.10 log units) above what was measured, and the stated range covers the measured number.
By their numbers in this assay, from the lowest: compound 1; then compound 3; then compound 4; then compound 2.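

Cyano on this aromatic carbon does not restore the number of the unsubstituted compound, as an 8.0-fold higher number from compound 1 to compound 4 (0.90 log units; beyond the scatter) shows in this assay, and a 3.2-fold higher number from compound 3 to compound 4 (0.51 log units; beyond the scatter) shows that it cannot stand in for bromo without a loss. Going by these compounds alone, it also lands clearly apart from fluoro, with a 3.5-fold lower number from compound 2 to compound 4 (0.54 log units; beyond the scatter), so the substituents at this position now form a graded series running from bromo through cyano to fluoro, and all three give higher numbers than hydrogen, with no compound among the four going against that. No accompanying measurement bears on what sets this order.

The compounds shown leave open whether chloro, methoxy, an amine or a carboxylic acid on this carbon would fall within the same series, and whether any group here could give a lower number than hydrogen in compound 1. They also leave open whether bromo, cyano and fluoro would keep the same order on another carbon of this ring.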